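Adding a Third Methoxy to an Inactive Pair

The source may hold more compounds than are shown below. What is called first, only, known or untested is meant among the compounds shown, and "the series" means these compounds.

Compound 1 `COc1ccc(/C=C/C2CC=CC(=O)N2)cc1` and compound 2 `COc1ccc(/C=C/C2CC=CC(=O)N2)c(OC)c1` share one core. In a functional assay on HT-29 cells (Homo sapiens) for inhibition, read by sulforhodamine B assay, with a stated time of 48 h (a lower number here means a stronger inhibitor of growth, a higher number a weaker inhibitor of growth), compound 1 gives only a limit, > 1090 uM. In this assay compound 2 likewise gives only a limit, > 964 uM. Going by the values given here, the single measured step, a step that the two limits leave unreadable from compound 1 to compound 2, cannot be read, as both values sit at limits the limit of > 1090 uM in this assay, at which 1 of the 2 values shown sits, and (the limit of > 964 uM in this assay, at which 1 of the 2 values shown sits). Compound 3 `COc1cc(OC)c(OC)cc1/C=C/C1CC=CC(=O)N1` differs from compound 2 by methoxy in place of hydrogen on an aromatic carbon. No readable step bears on this change, so the expected step that the limit leaves unreadable from compound 2 to compound 3 in this assay is nothing beyond the scatter. Compound 3 is therefore estimated at 1000 uM, within 300 uM to 3000 uM, most likely again only a limit.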

Compound 3, concentration for growth inhibition (reported as GI): > 864 uM
Compound 3 gave a limit, no number (the forecaster's own chance of this, stated with the estimate: 80%); the middle value is on the limit's open side.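

In this assay compound 3 gives only a limit, > 864 uM, so its step from compound 2 cannot be read. As far as these compounds go, whether methoxy in place of hydrogen changes growth inhibition on the shared core remains open.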